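The source may report more compounds than this note shows. Statements on the series, on what has been measured and on what is new or still open speak of the compounds shown alone.

Measured so far in an assay on isolated protein for binding affinity to Equilibrative nucleoside transporter 1 (Homo sapiens); on this read-out lower numbers stand for stronger inhibition and higher numbers for weaker inhibition: compound 1 `Cc1cccc(CSc2ncnc3c2ncn3[C@@H]2O[C@H](CO)[C@@H](O)[C@H]2O)c1` gives 12000 nM; compound 2 `Cc1ccc(CSc2ncnc3c2ncn3[C@@H]2O[C@H](CO)[C@@H](O)[C@H]2O)cc1` gives 457 nM.

Going by the values given here, compound 2 stands at the lowest of the two numbers; the only other point is compound 1, and the step of a 26-fold lower number from compound 1 to compound 2 (1.42 log units; beyond the scatter) shows that moving the methyl group around the phenyl ring alone shifts this assay far beyond the scatter.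

Compound 3 `OC[C@H]1O[C@@H](n2cnc3c(CSc4ccccc4Br)ncnc32)[C@H](O)[C@@H]1O` is not yet measured. Its change from compound 2 is ((2-bromophenyl)sulfanyl)methyl in place of (4-methylbenzyl)sulfanyl on an aromatic carbon. This is a larger rearrangement than the measured step: the sulfur is now attached directly to the phenyl ring rather than to the methylene, and the methyl group gives way to a bromine at a different ring position. Among the compounds with values here, the one step that bears on it, a 26-fold lower number from compound 1 to compound 2 (1.42 log units; beyond the scatter), says only that the series is sensitive to where the ring substituent sits; nothing measured reports on the swapped linker or on bromine. A step toward weaker binding is therefore expected, with wide uncertainty, roughly a 6.6-fold higher number from compound 2 to compound 3 (0.82 log units; beyond the scatter). Compound 3 is estimated at 3000 nM, in the range 500 nM to 15000 nM.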

Compound 3, half-maximal inhibitory concentration: 2400 nM
Beside the measured number, compound 3's estimate is 1.3-fold (0.10 log units) above it; measured number inside the range.
By their numbers in this assay, from the lowest: compound 2; then compound 3; then compound 1.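

In this assay, the ((2-bromophenyl)sulfanyl)methyl group on the aromatic carbon places compound 3 in the middle of the series, with a 5.3-fold higher number from compound 2 to compound 3 (0.72 log units; beyond the scatter) and a 5.0-fold lower number from compound 1 to compound 3 (0.70 log units; beyond the scatter). This position therefore tolerates a sulfur bound directly to the phenyl ring, with the methylene on the core side, without the number going past that of compound 1, although the (4-methylbenzyl)sulfanyl group of compound 2 still gives the lowest number of the three. Nothing available explains why the numbers fall in this order.

From the compounds shown here alone, both steps change the order of sulfur and methylene and also the ring substituent, so the share of each change remains unknown, and a bromine-bearing benzyl sulfanyl group or a methyl-bearing phenyl sulfanyl methyl group would be needed to separate them. Also open, going by these compounds, is how this position responds to groups of another kind on the phenyl ring, such as an amine or a carboxylic acid, or to a longer chain carrying that ring.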